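Adding chloro to compound 2

A few compounds are considered here, and "the series" means these few. Any claim that something is new, unique, unknown or untested is made for them only; others in the source may bear on it.

Among the compounds with values here, compound 2 `COc1ccc(-c2nc3sc(-c4ccccc4)cn3n2)cc1` gives 34% in a functional assay on SNB-75 cells (Homo sapiens) for inhibition, read by sulforhodamine B assay, with a stated time of 48 h, tested at 10 uM (a higher number here means more inhibition of growth at the concentration tested, a lower number less inhibition of growth), the highest of the three numbers so far. Compound 1 `C/C(=N\O)c1ccc(NC(=O)Cn2nc(-c3ccc(Cl)cc3)nc2N)cc1` gives 12% and compound 3 `CC(=O)c1ccc(NC(=O)Cn2nc(C(F)(F)F)nc2N)cc1` gives 12.5%, both lower than compound 2 by more than the usual scatter.

Compound 4 `COc1ccc(-c2nc3sc(-c4ccc(Cl)cc4)cn3n2)cc1` keeps the core of compound 2 and turns phenyl into 4-chlorophenyl: chloro in place of hydrogen on an aromatic carbon. This places chloro in place of hydrogen on an aromatic carbon, para to a large group.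

Within the data shown here, no two measured compounds differ in one place only, so the series offers no direct measure of this change. The 4-chlorophenyl group also occurs in compound 1 at 12%, but that compound differs from compound 4 in too much else to guide the estimate. The starting point is therefore compound 2 at 34%. The estimated step of a number 3 percentage points higher from compound 2 to compound 4 (within the scatter) is small and upward, and it is expected to stay within the scatter. For compound 4 the expected value is 37%, with an estimated range of 19% to 57%.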

Compound 4, percent growth inhibition at one concentration: -1.66%
Estimate against measurement, compound 4: 38.7 percentage points above, and the stated range ends above it.
By their numbers in this assay, from the lowest: compound 4; then compounds 1 and 3 (each within the scatter of the next); then compound 2.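

In this assay, the series now has its first one-place comparison: a number 35.7 percentage points lower from compound 2 to compound 4 (beyond the scatter), with chloro in place of hydrogen on an aromatic carbon, para to a large group. This position on the core of compound 2 is therefore not indifferent to change, as with a single added chlorine atom compound 4 gives -1.66% at the concentration tested. No measurement at hand speaks to the reason for this drop.

One step cannot show whether the drop belongs to chloro itself or would follow any group at this place, a question that fluoro, methyl or an amine on the same carbon would address. Also open, on these data alone, is whether chloro at another carbon of this phenyl ring would give a similar number.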